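The source may hold more compounds than are shown below. What is called first, only, known or untested is meant among the compounds shown, and "the series" means these compounds.

Measured in an ADME assay on A549 cells (Homo sapiens) for cytotoxicity, read by resazurin assay, with a stated time of 48 h; a lower number here means that less compound is tolerated, a higher number that more compound is tolerated:

- Compound 1 `COc1ccc(CNc2ccc(NC(=O)c3cc(Cl)ccc3O)c(Cl)c2)cc1`: 80700 nM
- Compound 2 `O=C(Nc1ccc(NCc2ccc(O)cc2)cc1Cl)c1cc(Cl)ccc1O`: 116000 nM

For the measured compounds named here, these two numbers cannot be told apart, as the only measured step is a 1.4-fold higher number from compound 1 to compound 2 (0.16 log units; within the scatter). Going by the values given here, compound 2 therefore stands level with the only other measured compound.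

Compound 3 `O=C(Nc1ccc(NCc2cc(Cl)cc(Cl)c2)cc1Cl)c1cc(Cl)ccc1O` carries a larger change: 3,5-dichlorophenyl in place of 4-hydroxyphenyl on a saturated chain carbon bound to a nitrogen on an aromatic ring. The measured step, hydrogen in place of methyl on an oxygen on an aromatic ring, bears on this only weakly. It stayed within the scatter, and here the whole 4-hydroxyphenyl leaves. Among the compounds with values here, no measured compound carries 3,5-dichlorophenyl, so the data give neither size nor direction directly. As a judgement from the structural change alone, a moderately lower number is expected in this assay, with wide uncertainty. The expected step is a 3.3-fold lower number from compound 2 to compound 3 (0.52 log units; beyond the scatter). Compound 3 is estimated at 35000 nM, with an expected range from 8000 nM to 120000 nM.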

Compound 3, half-maximal cytotoxic concentration: 13300 nM
Compound 3: the middle estimate sits 2.6-fold (0.42 log units) above what was measured, within the range that was stated.
By their numbers in this assay, from the lowest: compound 3; then compounds 1 and 2 (each within the scatter of the next).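

At this place, on a saturated chain carbon bound to a nitrogen on an aromatic ring, exchanging the whole aromatic group shifts the number in this assay in a way that changing only the group on the oxygen did not: there is an 8.7-fold lower number from compound 2 to compound 3 (0.94 log units; beyond the scatter), and a 6.1-fold lower number from compound 1 to compound 3 (0.78 log units; beyond the scatter). Whether 4-hydroxyphenyl or 4-methoxyphenyl gives way to 3,5-dichlorophenyl, the fall lies beyond the scatter, so this position is not indifferent to the group it carries. Nothing measured here accounts for that fall.

The compounds shown leave open whether a single chlorine on the phenyl ring would give the same fall, or whether trifluoromethyl groups would. Going by these compounds, it also remains open how an amine on that ring, or a longer chain leading to it, would read in this assay.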